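The source may hold more compounds than are shown below. What is called first, only, known or untested is meant among the compounds shown, and "the series" means these compounds.

Measured in an assay on HeLa cells for displacement of a labelled ligand from 5-hydroxytryptamine receptor 6 (Homo sapiens); a lower number here means a stronger inhibitor, a higher number a weaker inhibitor:

Compound 1, `Cc1c(S(=O)(=O)c2ccccc2)c2cccnc2n1CCN`, gives 4.2 nM.
Compound 2, `Cc1c(S(=O)(=O)c2ccccc2)c2cccnc2n1CCN(C)C`, gives 4.7 nM.
Compound 3, `CN(C)CCn1cc(S(=O)(=O)c2cc(Cl)cc(Cl)c2)c2cccnc21`, gives 4.3 nM.

Compound 1 and compound 2 share one core and differ in a single place: amino in place of dimethylamino on a saturated chain carbon, two bonds along the chain from an aromatic nitrogen. That change made the step of a 1.1-fold lower number from compound 2 to compound 1 (0.05 log units; within the scatter), so in this assay the two are not told apart.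

Compound 3 is built on a different core, and the difference between the two cores is not broken down here. Its value sits alongside those of compound 1 and compound 2 with no difference that the assay can resolve.

Compound 4, `NCCn1cc(S(=O)(=O)c2cc(Cl)cc(Cl)c2)c2cccnc21`, is not yet measured. Going by the values given here, it differs from compound 3 by amino in place of dimethylamino on a saturated chain carbon, two bonds along the chain from an aromatic nitrogen, which is the same change, at the same kind of place, as the one made from compound 2 to compound 1. Placed beside the measured step of a 1.1-fold lower number from compound 2 to compound 1 (0.05 log units; within the scatter), the step from compound 3 to compound 4 is expected to be a 1.1-fold lower number from compound 3 to compound 4 (0.03 log units; within the scatter), resting only on that one earlier example on the other core. Compound 4 is therefore estimated at 4 nM, with a likely range from 2 nM to 8.5 nM.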

Compound 4, inhibition constant: 2.9 nM
Estimate against measurement, compound 4: 1.4-fold (0.14 log units) above; the range from low to high includes it.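

In this assay, putting amino in place of dimethylamino on the core of compound 3 gives a 1.5-fold lower number from compound 3 to compound 4 (0.17 log units; within the scatter), so this pair, like the pair on the other core, is not told apart. Set side by side, the two cases show that the change carries over between these cores without a difference the assay can resolve: the same change on two cores in this assay, a 1.1-fold lower number (0.05 log units; within the scatter) from compound 2 to compound 1 and a 1.5-fold lower number (0.17 log units; within the scatter) from compound 3 to compound 4, 1.3-fold (0.12 log units) apart, within the scatter of two such steps

Going by these compounds alone, this agreement rests on only two pairs, and neither step is larger than the usual scatter, so it shows that the swap made no clear difference on these two cores, not that the same would hold on any other core.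

The compounds shown leave open what a methylamino group, a pyrrolidine ring or a hydroxyl group would do in place of the amine at the end of the 2-aminoethyl chain. They also leave open whether a longer chain carrying the same amine would stay as hard to tell apart.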